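The source may hold more compounds than are shown below. What is called first, only, known or untested is meant among the compounds shown, and "the series" means these compounds.

Working notes on the series. Compound 1 `O=C(O)CC(CC(=O)NNC(=O)CCCCNc1ccccn1)c1ccc(Cl)cc1` and compound 2 `O=C(O)CC(CC(=O)NNC(=O)CCCCNc1ccccn1)c1ccc(Br)cc1` share one core. In a physicochemical assay for lipophilicity (on this read-out higher numbers stand for higher lipophilicity and lower numbers for lower lipophilicity), compound 1 gives 2.63 and compound 2 gives 2.9. The change between them, (bromo in place of chloro on an aromatic carbon), made a number 0.27 log units higher from compound 1 to compound 2 (within the scatter). Compound 3 `O=C(O)CC(NC(=O)NNC(=O)CCCCNc1ccccn1)c1ccc(Cl)cc1` has a different core; the difference between the two cores is not broken down here. In this assay compound 3 gives 2.2, the lowest of the three numbers, with compound 1 nearer and compound 2 further off, both beyond the scatter. Compound 4 `O=C(O)CC(NC(=O)NNC(=O)CCCCNc1ccccn1)c1ccc(Br)cc1` is not yet measured. It differs from compound 3 by bromo in place of chloro on an aromatic carbon, the same change as between compound 1 and compound 2, occurring twice among these compounds. The expectation rests on compound 1 and compound 2 and their step of a number 0.27 log units higher from compound 1 to compound 2 (within the scatter). For compound 4 the expected step in this assay is a number 0.27 log units higher from compound 3 to compound 4 (within the scatter). Compound 4 is thus estimated at 2.47, between 2.2 and 2.75.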

Compound 4, partition coefficient: 2.47
Compound 4: middle estimate and measured number agree at the digits printed, within the range that was stated.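

In this assay, bromo in place of chloro on an aromatic carbon gives a number 0.27 log units higher from compound 3 to compound 4 (within the scatter) on one core and a number 0.27 log units higher from compound 1 to compound 2 (within the scatter) on the other, so the step carries over between these two cores at the digits printed. This rests on two pairs only, and as both steps lie within the scatter, neither can be told apart from repeat variation, so the agreement does not establish a real shift that transfers. No evidence bearing on why the two steps agree is at hand.

The compounds shown carry only chloro or bromo at this place on the ring, so what fluoro, an amine or a methoxy group there would give remains open. Going by these compounds, whether the step holds on a third core also remains open.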